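The source may hold more compounds than are shown below. What is called first, only, known or untested is meant among the compounds shown, and "the series" means these compounds.

Measured so far in an ADME assay on microsomes from liver (Mus musculus) for metabolic stability; a lower number here means that the compound disappears faster, a higher number that the compound lasts longer:
compound 1 `O=C(C[C@H]1CC[C@]2(CC1)OO[C@]1(O2)C2CC3CC(C2)CC1C3)N1CCNCC1` gives 0.802 h;
compound 2 `NC1CCN(C(=O)C[C@H]2CC[C@]3(CC2)OO[C@]2(O3)C3CC4CC(C3)CC2C4)CC1` gives 4.62 h;
compound 3 `O=C(C[C@@H]1CCC[C@]2(C1)OOC1(O2)C2CC3CC(C2)CC1C3)N1CCNCC1` gives 0.425 h.

Compound 1 and compound 3 share the same atoms joined differently; the difference between the two cores is not broken down here. Compound 2 carries 4-aminopiperidin-1-yl in place of piperazin-1-yl on a carbonyl carbon, and this change gave a 5.8-fold higher number from compound 1 to compound 2 (0.76 log units; beyond the scatter) in this assay.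

Compound 4 `NC1CCN(C(=O)C[C@@H]2CCC[C@]3(C2)OOC2(O3)C3CC4CC(C3)CC2C4)CC1` is the unmeasured partner of compound 3 and differs from it by 4-aminopiperidin-1-yl in place of piperazin-1-yl on a carbonyl carbon, the same change as from compound 1 to compound 2, on the other core. For the measured compounds named here, compound 4 is expected to show a 5.6-fold higher number from compound 3 to compound 4 (0.75 log units; beyond the scatter) in this assay, a step of about the size already seen, because the earlier step of a 5.8-fold higher number from compound 1 to compound 2 (0.76 log units; beyond the scatter) is the only guide available. Compound 4 is therefore estimated at 2.4 h, within 1 h to 5.5 h.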

Compound 4, half-life: 1.41 h
Beside the measured number, compound 4's estimate is 1.7-fold (0.23 log units) above it, within the range that was stated.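

On the core of compound 3, 4-aminopiperidin-1-yl in place of piperazin-1-yl on a carbonyl carbon gave a 3.3-fold higher number from compound 3 to compound 4 (0.52 log units; beyond the scatter) in this assay. The change carries from one core to the other in the same direction, and the two steps do not differ in size beyond what repeat measurements would allow: the same change on two cores in this assay, a 5.8-fold higher number (0.76 log units; beyond the scatter) from compound 1 to compound 2 and a 3.3-fold higher number (0.52 log units; beyond the scatter) from compound 3 to compound 4, 1.7-fold (0.24 log units) apart, within the scatter of two such steps. This rests on two pairs only, so it does not show that the step would hold on further cores, nor does it explain why the number rises.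

Open, on these data alone, is whether 4-hydroxypiperidin-1-yl or morpholin-4-yl on the carbonyl carbon would give a similar step, and so whether the amine of 4-aminopiperidin-1-yl is needed for it.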